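Swapping propyl for 4-methoxyphenyl on the ring nitrogen

The source may hold more compounds than are shown below. What is called first, only, known or untested is meant among the compounds shown, and "the series" means these compounds.

Compound 1 `CCCn1ccnc1-c1cc(OC)c(OC)c(OC)c1` carries a propyl group on a ring nitrogen of its core. In a functional assay on MDA-MB-468 cells (Homo sapiens) for antiproliferative activity, read by MTT assay, with a stated time of 72 h (a lower number here means a stronger inhibitor, a higher number a weaker inhibitor), compound 1 gives > 100000 nM, which is a limit of the assay rather than a number. This places compound 1 at the limit of > 100000 nM in this assay, at which 2 of the 3 values shown sit. Compound 2 `COc1cc(-c2nccn2S(=O)(=O)c2ccccc2)cc(OC)c1OC` gives > 100000 nM in this assay, again a limit. Compound 3 `COc1cc(-c2nccn2-c2cccc([N+](=O)[O-])c2)cc(OC)c1OC` gives 7200 nM in this assay, a measured number. Compound 4 `COc1ccc(-n2ccnc2-c2cc(OC)c(OC)c(OC)c2)cc1` differs from compound 1 by 4-methoxyphenyl in place of propyl on an aromatic nitrogen. Among the measured compounds shown here, compound 3 shows 7200 nM as the only measured number here. Compound 4 is expected to come to a measurable value, a step of an at least 33-fold lower number from compound 1 to compound 4 (1.52 log units; beyond the scatter). Compound 4 is estimated at 3000 nM, within 500 nM to 20000 nM.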

Compound 4, half-maximal inhibitory concentration: 500 nM
Estimate against measurement, compound 4: 6.0-fold (0.78 log units) above, within the range that was stated.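

In this assay compound 1 gives > 100000 nM, which is a limit of the assay and not a number. With 4-methoxyphenyl in place of propyl on the aromatic nitrogen, the result is an at least 200-fold lower number from compound 1 to compound 4 (2.30 log units; beyond the scatter). This first readable step at this position shows that the group on this nitrogen can decide whether the shared core gives a measurable value at all. The change replaces a chain with a ring and adds a methoxy group at once, and the compounds shown cannot separate those two parts. A plain phenyl or a benzyl group on the same nitrogen would help to tell them apart.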